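A Second Methoxy on Compound 3

The compounds below may be only part of what the source reports. "The series", "measured", "known", "first", "only" and "open" are said of these compounds alone.

In a functional assay on A549 cells (Homo sapiens) for inhibition, read by MTT assay, with a stated time of 24 h (on this read-out higher numbers stand for weaker inhibition of growth and lower numbers for stronger inhibition of growth), three compounds have been measured so far. Compound 1 `COc1ccc2c(c1)c(-c1nc3ccccc3n1C(=O)c1ccc(OC)c(OC)c1)cn2C` gives 2700 nM, compound 2 `Cn1cc(-c2nc3ccccc3n2C(=O)c2ccccc2)c2cc(Br)ccc21` gives 23100 nM, and compound 3 `COc1cccc(C(=O)n2c(-c3cn(C)c4ccc(Br)cc34)nc3ccccc32)c1` gives 10800 nM. Compound 3 therefore holds the second highest of the three numbers, with compound 2 above it and compound 1 lowest.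

Compound 4 `COc1ccc(C(=O)n2c(-c3cn(C)c4ccc(Br)cc34)nc3ccccc32)cc1OC` is compound 3 with its 3-methoxyphenyl turned into 3,4-dimethoxyphenyl: methoxy in place of hydrogen on an aromatic carbon. The change is methoxy in place of hydrogen on an aromatic carbon. One measured step is of this same kind, a 2.1-fold lower number from compound 2 to compound 3 (0.33 log units; beyond the scatter), a modest change that lies beyond the scatter. For the measured compounds named here, no measured step joins compound 1 to compound 4, so compound 1 sets no size for this one.

A single step is thin evidence, but a modest move toward a lower number is expected in this assay again. The expected change is a 2.0-fold lower number from compound 3 to compound 4 (0.29 log units; within the scatter). For compound 4 the estimate is 5500 nM, with an expected range of 2300 nM to 12000 nM.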

Compound 4, concentration for 50% growth inhibition: 3400 nM
For compound 4 the middle estimate is 1.6-fold (0.21 log units) above the measured one, within the range that was stated.
By their numbers in this assay, from the lowest: compounds 1 and 4 (each within the scatter of the next); then compound 3; then compound 2.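

In this assay, a methoxy placed ortho to a methoxy group and para to a large group gives a 3.2-fold lower number from compound 3 to compound 4 (0.50 log units; beyond the scatter) and so adds to what the first methoxy gave, while the full replacement of phenyl by 3,4-dimethoxyphenyl amounts to a 6.8-fold lower number from compound 2 to compound 4 (0.83 log units; beyond the scatter) over the unsubstituted ring. Once the 3,4-dimethoxyphenyl is present, the swap of methoxy for bromo on the other aromatic ring gives a 1.3-fold higher number from compound 1 to compound 4 (0.10 log units; within the scatter) and cannot be told from scatter in this pair. Nothing available bears on the reason for the gain from the second methoxy.

As far as these compounds go, whether a hydroxy group, an amine or a longer chain such as ethoxy on this same carbon would act as methoxy does remains open. Also open, from the compounds shown here alone, is whether a lone methoxy at this place, without the neighbouring one, would give any step at all.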